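The source may hold more compounds than are shown below. What is called first, only, known or untested is meant among the compounds shown, and "the series" means these compounds.

Measured compounds in this assay:
- compound 1, `Cn1ncc(Cl)c1-c1cc(C(=O)N[C@@H]2CN[C@H](CC(=O)NC3CC3)C[C@H]2c2ccc(Cl)c(Cl)c2)oc1Cl`: 190 nM
- compound 2, `Cn1ncc(Cl)c1-c1cc(C(=O)N[C@@H]2CN[C@H](CCO)C[C@H]2c2ccc(F)c(F)c2)oc1Cl`: 60 nM
- compound 3, `CNC(=O)C[C@@H]1C[C@@H](c2ccc(F)c(F)c2)[C@H](NC(=O)c2cc(-c3c(Cl)cnn3C)c(Cl)o2)CN1`: 50 nM

In a functional assay on LNCaP cells (Homo sapiens) for antiproliferative activity (on this read-out higher numbers stand for weaker inhibition and lower numbers for stronger inhibition), compound 1 gives 190 nM, the highest number of the three. Compound 2 gives 60 nM and compound 3 gives 50 nM, both below compound 1 by more than the scatter; compounds 2 and 3 sit within the scatter of each other.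

Compound 4, `COCC[C@@H]1C[C@@H](c2ccc(Cl)c(Cl)c2)[C@H](NC(=O)c2cc(-c3c(Cl)cnn3C)c(Cl)o2)CN1`, has not been measured. It differs from compound 1 as follows: methoxymethyl in place of cyclopropylcarbamoyl on a saturated chain carbon bound to a saturated ring carbon. Among the compounds with values here, one measured step touches the same place on the saturated chain carbon bound to a saturated ring carbon, namely a 1.2-fold lower number from compound 2 to compound 3 (0.08 log units; within the scatter), which exchanged a hydroxymethyl for a methylcarbamoyl without a shift beyond the scatter. Within the data shown here, compound 2 and compound 3 carry a different aryl substitution from compound 1 and compound 4, so no step isolates that change, and the comparison is indirect. Among the measured compounds shown here, the one relevant step suggests that groups at this position can be swapped with little effect, and the change from compound 1 to compound 4 is therefore expected to stay close to the scatter: a 1.2-fold lower number from compound 1 to compound 4 (0.07 log units; within the scatter).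

Compound 4 is estimated at 160 nM, with a range from 60 nM to 420 nM.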

Compound 4, half-maximal inhibitory concentration: 250 nM
For compound 4 the middle estimate is 1.6-fold (0.19 log units) below the measured one; measured number inside the range.
By their numbers in this assay, from the lowest: compounds 3 and 2 (each within the scatter of the next); then compounds 1 and 4 (each within the scatter of the next).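

In this assay, the exchange of cyclopropylcarbamoyl for methoxymethyl on a saturated chain carbon bound to a saturated ring carbon gives a 1.3-fold higher number from compound 1 to compound 4 (0.12 log units; within the scatter). The earlier step at this place covered only hydroxymethyl and methylcarbamoyl on the fluorine-bearing aryl group, whereas this one sits on the chlorine-bearing aryl group and removes the three-membered ring and the amide hydrogen, so the tolerance at this place now extends to a second aryl substitution and to a larger exchange, with both steps at this place within the scatter and neither compound pair going against that reading. No measurement in hand bears on why the read-out stays level across this exchange.

Still open is whether a primary amine, a carboxylic acid or a longer chain ending in a morpholine ring at the same place would also leave the number within the scatter, since all groups shown so far are neutral chains ending in an alcohol, an ether or an amide. No pair shown differs in the aryl substitution alone, so the effect of chlorine against fluorine on that aryl group remains unresolved.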